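Stripping the Aryl Substituent from Compound 3

A few compounds are considered here, and "the series" means these few. Any claim that something is new, unique, unknown or untested is made for them only; others in the source may bear on it.

For the measured compounds named here, in a functional assay on LNCaP cells (Homo sapiens) for cytotoxicity, read by MTT assay, with a stated time of 48 h (a lower number here means a stronger inhibitor, a higher number a weaker inhibitor), compound 3 `Clc1ccc(-c2nc(-c3c[nH]c4ccccc34)co2)cc1` gives 505000 nM, the highest of the three numbers measured so far. Its nearest neighbour is compound 1 `c1ccc(-c2nc(-c3c[nH]c4ccccc34)co2)cc1`, which in this assay gives 461000 nM; the step of a 1.1-fold higher number from compound 1 to compound 3 (0.04 log units; within the scatter) lies within the scatter. Compound 2 `c1ccc2c(-c3coc(-c4ccncc4)n3)c[nH]c2c1` in this assay gives 238000 nM, and the step of a 2.1-fold higher number from compound 2 to compound 3 (0.33 log units; beyond the scatter) is a modest one beyond the scatter, whereas a 1.9-fold lower number from compound 1 to compound 2 (0.29 log units; within the scatter) stays within it. Compound 4 `c1ccc2c(-c3cocn3)c[nH]c2c1` has not yet been measured; the change from compound 3 is hydrogen in place of 4-chlorophenyl on an aromatic carbon. Going by the values given here, none of the measured steps removes the aryl group altogether: the steps of a 1.1-fold higher number from compound 1 to compound 3 (0.04 log units; within the scatter) and a 1.9-fold lower number from compound 1 to compound 2 (0.29 log units; within the scatter) vary only what sits on or in that ring, and both are small. Within the measured set the aryl group thus makes little difference, so the step of a 1.3-fold higher number from compound 3 to compound 4 (0.11 log units; within the scatter) is expected to stay within or only modestly beyond the scatter, leaning towards a weaker inhibitor. Compound 4 is estimated at 650000 nM, with a range from 200000 nM to 2000000 nM.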

Compound 4, half-maximal inhibitory concentration: 382000 nM
The estimate for compound 4 lay 1.7-fold (0.23 log units) above the measured number; low and high end bracket the measured number.
By their numbers in this assay, from the lowest: compounds 2, 4, 1 and 3 (each within the scatter of the next, the first and the last beyond it).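

In this assay, taking the aryl group off entirely moves the number by no more than the scatter, whichever of the three groups leaves (a 1.3-fold lower number from compound 3 to compound 4 (0.12 log units; within the scatter); a 1.6-fold higher number from compound 2 to compound 4 (0.21 log units; within the scatter); a 1.2-fold lower number from compound 1 to compound 4 (0.08 log units; within the scatter)). The earlier compounds shown here only varied the group on this aromatic carbon, next to the ring nitrogen and next to the ring oxygen, whereas compound 4 shows that hydrogen alone there cannot be told apart from 4-chlorophenyl, pyridin-4-yl or phenyl. Nothing available explains this lack of response at the position.

From the compounds shown here alone, it remains open whether a group of another kind on this carbon, such as an amine, a carboxylic acid or a longer alkyl chain, would move the number beyond the scatter. The compounds shown also leave open whether a change elsewhere on the shared core would do so.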